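A few compounds are considered here, and "the series" means these few. Any claim that something is new, unique, unknown or untested is made for them only; others in the source may bear on it.

In a functional assay on HL-60 cells (Homo sapiens) for inhibition, read by luminescence, with a stated time of 72 h, tested at 5 uM (on this read-out lower numbers stand for less inhibition of growth and higher numbers for more inhibition of growth at the one concentration tested), compound 2 (`C=CS(=O)(=O)NC/C=C/c1cc(OC)cc(O)c1C(=O)OCC1CCCCC1`) gives 7.5% and compound 1 (`C=CS(=O)(=O)NC/C=C/c1cc(OC)cc(O)c1C(=O)OC(C)C`) gives 16.6%, two numbers within the scatter of each other. The next change leads to compound 3 (`C=CS(=O)(=O)NC/C=C/c1cc(OC)cc(O)c1C(=O)OCc1ccc(Br)cc1`): 4-bromophenyl in place of cyclohexyl on a saturated chain carbon bound to an oxygen next to a carbonyl group, with 4-bromophenyl in place of cyclohexyl on a saturated chain carbon bound to an oxygen next to a carbonyl group. For the measured compounds named here, one measured step bears on this change, cyclohexylmethyl in place of isopropyl at the same oxygen: a number 9.1 percentage points lower from compound 1 to compound 2 (within the scatter). That step stays inside the scatter. Going by the values given here, no aromatic group has yet been measured at this place, so the single step is weak guidance, and no step beyond the scatter is expected in this assay. The expected step is a number 4.5 percentage points higher from compound 2 to compound 3 (within the scatter). For compound 3 the estimate is 12%, with an expected range from 0% to 28%.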

Compound 3, percent growth inhibition at one concentration: 8.1%
Compound 3: middle estimate off by 3.9 percentage points, on the high side, and the stated range covers the measured number.
By their numbers in this assay, from the lowest: compounds 2, 3 and 1 (each within the scatter of the next).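

In this assay, for the compounds shown here, the first aromatic group at this place, 4-bromophenyl in place of cyclohexyl on a saturated chain carbon bound to an oxygen next to a carbonyl group, gives a number 0.6 percentage points higher from compound 2 to compound 3 (within the scatter), so an aromatic and a non-aromatic six-membered ring cannot be told apart here. Against the smaller starting group, 4-bromobenzyl in place of isopropyl on an oxygen next to a carbonyl group gives a number 8.5 percentage points lower from compound 1 to compound 3 (within the scatter), so none of the three groups at this oxygen separates from the others, whether saturated, branched or aromatic with bromine. Nothing available explains these numbers or links them to any property of the groups.

Going by these compounds, whether any group at this oxygen can move growth inhibition beyond the scatter at this one concentration stays open. Also open, on these data alone, is what a plain benzyl without the bromine, a longer chain, or a chain ending in an amine or a carboxylic acid would give at this oxygen.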